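The compounds below may be only part of what the source reports. "The series", "measured", "known", "first", "only" and "open" are said of these compounds alone.

Compound 1 `COc1nn(C)c2ncnc(NS(=O)(=O)c3cccc(Cl)c3Cl)c12` and compound 2 `COc1nn(C(C)C)c2ncnc(NS(=O)(=O)c3cccc(Cl)c3Cl)c12` share one core and differ only at a nitrogen of the fused ring system. In a functional assay on cells for antagonist activity at C-C chemokine receptor type 4 (Homo sapiens), read by GTPgammaS binding (a lower number here means a stronger inhibitor, a higher number a weaker inhibitor), compound 1 gives 63.1 nM, while compound 2 gives 251 nM. Of the two numbers, compound 1 holds the lower one, and the step of a 4.0-fold higher number from compound 1 to compound 2 (0.60 log units; beyond the scatter) stands beyond the scatter. Compound 3 `CNc1nc(NS(=O)(=O)c2cccc(Cl)c2Cl)c2c(OC)nn(C)c2n1` keeps the methyl on that nitrogen and instead carries methylamino in place of hydrogen on an aromatic carbon. Going by the values given here, no measured pair shows a change at this carbon: the one known step concerns a group on a ring nitrogen and therefore does not bear on the present change. With nothing to lean on, the expectation for compound 3 is a number near that of compound 1, with a step of a 1.3-fold lower number from compound 1 to compound 3 (0.10 log units; within the scatter) in this assay that need not exceed the scatter. Compound 3 is thus estimated at 50 nM in this assay, with a likely range from 15 nM to 200 nM.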

Compound 3, half-maximal inhibitory concentration: 79.4 nM
For compound 3 the middle estimate is 1.6-fold (0.20 log units) below the measured one; low and high end bracket the measured number.
By their numbers in this assay, from the lowest: compounds 1 and 3 (each within the scatter of the next); then compound 2.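

This aromatic carbon, between two ring nitrogen atoms, can carry methylamino in place of hydrogen without a clear cost in this assay, where the comparison reads a 1.3-fold higher number from compound 1 to compound 3 (0.10 log units; within the scatter). Going by these compounds alone, the change adds one hydrogen-bond donor and one hydrogen-bond acceptor by count, yet compounds 1 and 3 cannot be told apart in this measurement, so this is the first sign that the position has room for a substituent. Nothing available explains why the added group makes so little difference.

The compounds shown leave open whether a plain amine, a longer chain such as propylamino, or a ring such as morpholine would be accepted at this carbon equally well. With only one substituent shown here, they also cannot reveal any trend with the size of the group.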